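The source may report more compounds than this note shows. Statements on the series, on what has been measured and on what is new or still open speak of the compounds shown alone.

Working notes on the series.

Compound 1 `Nc1nc(N)c2c(-c3ccsc3)cn([C@@H]3O[C@H](CO)[C@@H](O)[C@H]3O)c2n1` gives in a functional assay on CCRF-CEM cells (Homo sapiens), read by MTT assay, with a stated time of 72 h (a higher number here means a weaker inhibitor, a lower number a stronger inhibitor), a value of > 20000 nM, which is a limit of the assay and not a number. Compound 2 `Nc1nc(N)c2c(-c3ccoc3)cn([C@@H]3O[C@H](CO)[C@@H](O)[C@H]3O)c2n1` gives in this assay > 20000 nM, again only a limit. Compound 3 `Cc1nc(N)c2c(-c3ccsc3)cn([C@@H]3O[C@H](CO)[C@@H](O)[C@H]3O)c2n1` gives in this assay > 20000 nM, once more a limit rather than a number. Among the measured compounds shown here, every value so far sits at the same limit (the limit of > 20000 nM in this assay, at which 3 of the 3 values shown sit), so compound 3 stands where the whole series stands: no number has yet been read for any member. The two steps that connect the measured compounds, a step that the two limits leave unreadable from compound 1 to compound 2 and a step that the two limits leave unreadable from compound 1 to compound 3, cannot be sized for this reason.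

Compound 4 `C#Cc1cn([C@@H]2O[C@H](CO)[C@@H](O)[C@H]2O)c2nc(C)nc(N)c12` differs from compound 3 by ethynyl in place of thiophen-3-yl on an aromatic carbon. For the measured compounds named here, neither of the measured steps concerns this kind of exchange, and both are unreadable in any case, so no measured step gives a direction or a size for it. The expectation for the step of an at least 3.3-fold lower number from compound 3 to compound 4 (0.52 log units; beyond the scatter) therefore rests on the bare fact that compound 3 sits at the limit, and is an estimate with wide uncertainty. Compound 4 is expected to give in this assay about 6000 nM, within a range from 300 nM to 40000 nM, with a real chance that only a limit is reported again.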

Compound 4, half-maximal inhibitory concentration: > 20000 nM
Compound 4 was reported as a limit; the forecaster's own chance of this, stated with the estimate: 40%; at least 3.3-fold (0.52 log units) between middle value and limit.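

No new step can be read: the exchange of thiophen-3-yl for ethynyl from compound 3 to compound 4 joins two limits, like every other step in the series, and stays unsized: the limit of > 20000 nM in this assay, at which 4 of the 4 values shown sit.

The compounds shown leave open whether any exchange on the shared core gives a readable number in this assay, and in which direction each exchange acts.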